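From methylsulfanyl to hydroxy: estimating compound 4

A few compounds are considered here, and "the series" means these few. Any claim that something is new, unique, unknown or untested is made for them only; others in the source may bear on it.

compound 1 `CC(=O)c1cc(C)c(OCCCCC#N)cc1O` — 35%
compound 2 `CCCc1cc(C(C)=O)c(O)cc1OCCCCC#N` — 37%
compound 3 `CSCc1cc(C(C)=O)c(O)cc1OCCCCCCC#N` — 64%

All three were tested in an assay on isolated protein for binding affinity to leukotriene B4 receptor 1 (Homo sapiens), tested at 1 uM; on this read-out lower numbers stand for less inhibition and higher numbers for more inhibition at the one concentration tested (going by the name of the read-out). Compound 3 stands highest of the three numbers; compound 2 lies nearest, and compound 1 lies furthest, both gaps beyond the scatter. Compound 3 and compound 2 differ in more than one place, so their values only show that compound 3 reads higher. Among the measured compounds shown here, the single one-place step measured so far is a number 2 percentage points higher from compound 1 to compound 2 (within the scatter); it concerns a different group and gives no direct guide.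

Compound 4 `CC(=O)c1cc(CO)c(OCCCCCCC#N)cc1O` differs from compound 3 by hydroxy in place of methylsulfanyl on a saturated chain carbon bound to an aromatic carbon. For the measured compounds named here, no measured step bears on this exchange. Going by the values given here, since the only available step sits within the scatter and compound 3 gives 64%, a modest downward step is expected, a number 14 percentage points lower from compound 3 to compound 4 (beyond the scatter), with wide uncertainty. Compound 4 is therefore estimated at 50%, in the range 25% to 75%, in this assay .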

Compound 4, a percentage reported as inhibition, at one concentration (the size of the read-out at that concentration, not a potency): 8%
Compound 4: middle estimate off by 42 percentage points, on the high side; measured number outside the range, below it.
By their numbers in this assay, from the lowest: compound 4; then compounds 1 and 2 (each within the scatter of the next); then compound 3.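

The exchange of methylsulfanyl for hydroxy on a saturated chain carbon bound to an aromatic carbon gives, in this assay, a number 56 percentage points lower from compound 3 to compound 4 (beyond the scatter). This shows that what this place carries can matter a great deal, which the earlier step at a place of the same description, a number 2 percentage points higher from compound 1 to compound 2 (within the scatter), did not reveal, although that step replaced hydrogen with ethyl and was measured on a different pair of compounds. Nothing measured here accounts for the size of the new step.

The compounds shown leave open whether a methoxy, an amine or an ethylsulfanyl group at this place would read closer to compound 3 or to compound 4. They also leave open whether the same exchange would give a step of similar size with a shorter nitrile-bearing chain on the shared core.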